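The compounds below may be only part of what the source reports. "The series", "measured", "known", "first", "only" and "open" are said of these compounds alone.

Measured compounds:
Compound 1, `CN1CCC(c2c[nH]c3ccc(NC(=O)C4CC4)nc23)CC1`: 1700 nM
Compound 2, `CN1CCC(c2c[nH]c3ccc(NC(=O)c4ccc(C#N)cc4)nc23)CC1`: 310 nM
Compound 3, `CN1CCC(c2c[nH]c3ccc(NC(=O)c4ccc([N+](=O)[O-])cc4)nc23)CC1`: 270 nM

All three share a core and differ only in the group on the carbonyl carbon of the amide. In an assay for binding affinity to 5-hydroxytryptamine receptor 1B (Homo sapiens), read by radioligand binding (a higher number here means a weaker inhibitor, a lower number a stronger inhibitor), compound 3 gives the lowest of the three numbers, yet its value and that of compound 2 lie within the scatter of each other, as the step of a 1.1-fold lower number from compound 2 to compound 3 (0.06 log units; within the scatter) shows, so neither can be called the stronger of the two. Both aryl amides stand clearly apart from the cyclopropyl amide compound 1: the steps of a 5.5-fold lower number from compound 1 to compound 2 (0.74 log units; beyond the scatter) and a 6.3-fold lower number from compound 1 to compound 3 (0.80 log units; beyond the scatter) are modest but beyond the scatter.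

Compound 4, `CN1CCC(c2c[nH]c3ccc(NC(=O)c4ccncc4)nc23)CC1`, has not yet been measured. It differs from compound 3 by pyridin-4-yl in place of 4-nitrophenyl on a carbonyl carbon. For the measured compounds named here, the steps that bear on this change are the two aryl-for-cyclopropyl steps, which show that a six-membered aromatic ring on the carbonyl carbon is worth a modest gain, and the nitro-for-cyano step, which shows that exchanging one group on that ring changed little. Compound 4 keeps an aromatic ring but drops the group carried on it, so a small move toward a higher number is expected, a 1.7-fold higher number from compound 3 to compound 4 (0.22 log units; within the scatter), still well short of compound 1. Compound 4 is therefore estimated at 450 nM, within a range of 150 nM to 1400 nM.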

Compound 4, inhibition constant: 330 nM
Compound 4: middle estimate off by 1.4-fold (0.13 log units), on the high side; the measured number falls inside the stated range.
By their numbers in this assay, from the lowest: compounds 3, 2 and 4 (each within the scatter of the next); then compound 1.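

In this assay, the step of a 1.2-fold higher number from compound 3 to compound 4 (0.09 log units; within the scatter) and the step of a 1.1-fold higher number from compound 2 to compound 4 (0.03 log units; within the scatter) show that a carbon-only ring bearing a nitro or nitrile group is not needed at this position: a pyridin-4-yl ring on the carbonyl carbon, smaller and with no such group, stays within the scatter of both. The step of a 5.2-fold lower number from compound 1 to compound 4 (0.71 log units; beyond the scatter) is modest but beyond the scatter, so all three aromatic rings now stand apart from the cyclopropyl amide, and this separation holds for a ring carrying nitro, a ring carrying nitrile and a ring with a nitrogen atom in it. For the compounds shown here, the compounds show only that these groups can be exchanged at this position, and no accompanying measurement offers an explanation for it.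

The compounds shown leave open how a plain phenyl ring would read, which would separate the ring nitrogen of compound 4 from the nitro and nitrile groups of compound 3 and compound 2. On these data alone, it also remains open whether a ring carrying an amine or a carboxylic acid, or a longer alkyl chain in place of cyclopropyl, would keep or lose this level of binding.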